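Ethoxy in Place of Cyano: an Estimate for Compound 4

The source may report more compounds than this note shows. Statements on the series, on what has been measured and on what is new or still open speak of the compounds shown alone.

In a functional assay on HEK293 cells for agonist activity at Neuronal acetylcholine receptor; alpha4/beta2 (Homo sapiens), read by FLIPR (a higher number here means that more compound is needed for the effect, a lower number that less compound is needed), the three measured compounds give:
compound 1 `c1cncc(N2CC[C@H]3CN[C@H]3C2)c1`: 71 nM
compound 2 `N#Cc1cncc(N2CC[C@H]3CN[C@H]3C2)c1`: 1900 nM
compound 3 `N#Cc1cncc(N2CC[C@@H]3CN[C@@H]3C2)c1`: 1900 nM

Compound 2 stands level with compound 3, and together they give the highest numbers of the three; from compound 1 it is separated by a 27-fold higher number from compound 1 to compound 2 (1.43 log units; beyond the scatter). The step of no change at the digits printed from compound 2 to compound 3 (within the scatter) fits with the fact that compounds 2 and 3 differ only in the configuration as drawn.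

Compound 4 `CCOc1cncc(N2CC[C@H]3CN[C@H]3C2)c1` differs from compound 2 by ethoxy in place of cyano on an aromatic carbon. For the measured compounds named here, the only step that bears on this site is a 27-fold higher number from compound 1 to compound 2 (1.43 log units; beyond the scatter), where adding cyano to the bare ring of compound 1 raised the number strongly. Removing that cyano should undo part of this, but no measurement shows what ethoxy itself does at this place. The expected step is therefore a 5.4-fold lower number from compound 2 to compound 4 (0.73 log units; beyond the scatter) in this assay, with wide uncertainty. For compound 4 the estimate is 350 nM, expected between 70 nM and 1800 nM.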

Compound 4, half-maximal effective concentration: 620 nM
Beside the measured number, compound 4's estimate is 1.8-fold (0.25 log units) below it, and the stated range covers the measured number.
By their numbers in this assay, from the lowest: compound 1; then compound 4; then compounds 2 and 3 (each within the scatter of the next).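

Ethoxy in place of cyano gives a 3.1-fold lower number from compound 2 to compound 4 (0.49 log units; beyond the scatter) and so shows that the high number of compound 2 does not come with every group at this place. Ethoxy in place of hydrogen still gives an 8.7-fold higher number from compound 1 to compound 4 (0.94 log units; beyond the scatter) and so both groups shown here, cyano and ethoxy, leave the number higher than on the bare ring of compound 1. As far as these compounds go, whether methoxy, an amine or a longer chain such as butoxy would come closer to compound 1 stays open. Nothing shown explains why ethoxy and cyano differ at this place.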